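Acetylpiperidine replaces sulfonylpiperazine at the distal amine

This account rests on a few compounds, and the source may have more. Where it says the series, first, only, none or still open, it means among the compounds named here.

Compound 1 `CC(=O)N1CCN(CCN2CCC(CNC(=O)c3cccc4[nH]c(C(C)C)nc34)CC2)CC1`: 76%
Compound 2 `CS(=O)(=O)N1CCN(CC(O)CN2CCC(CNC(=O)c3cccc4[nH]cnc34)CC2)CC1`: 6%
Compound 3 `CC(C)c1nc2c(C(=O)NCC3CCN(CCN4CCN(S(C)(=O)=O)CC4)CC3)cccc2[nH]1`: 64%

In a functional assay for agonist activity at 5-hydroxytryptamine receptor 4 (Homo sapiens), read by cAMP accumulation (on this read-out lower numbers stand for smaller maximal responses and higher numbers for larger maximal responses), compound 3 holds the second highest of the three numbers. Compound 1 stands nearest to it, and the step of a number 12 percentage points lower from compound 1 to compound 3 (beyond the scatter) separates them. Compound 2 lies furthest away, far lower. Compound 4 `CC(=O)N1CCC(CN2CCC(CNC(=O)c3cccc4[nH]c(C(C)C)nc34)CC2)CC1` is not yet measured. It differs from compound 3 in one place: 1-acetylpiperidin-4-yl in place of (4-(methylsulfonyl)piperazin-1-yl)methyl on a saturated chain carbon bound to an amine nitrogen in a ring. For the measured compounds named here, the only step that bears on this change is a number 12 percentage points lower from compound 1 to compound 3 (beyond the scatter), a modest decrease when methylsulfonyl took the place of acetyl; compound 4 brings an acetyl amide back, though on a different ring. A small rise, within the scatter, is therefore expected as a number 8 percentage points higher from compound 3 to compound 4 (within the scatter). Compound 4 is estimated at 72%, in the range 50% to 90%.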

Compound 4, intrinsic activity: the largest response reached, in percent of the reference agonist's: 87%
Compound 4: the middle estimate sits 15 percentage points below what was measured, and the stated range covers the measured number.
By their numbers in this assay, from the lowest: compound 2; then compound 3; then compound 1; then compound 4.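

In this assay, 1-acetylpiperidin-4-yl in place of (4-(methylsulfonyl)piperazin-1-yl)methyl gives a number 23 percentage points higher from compound 3 to compound 4 (beyond the scatter) on this saturated chain carbon. With the acetyl present on both sides, 1-acetylpiperidin-4-yl in place of (4-acetylpiperazin-1-yl)methyl still gives a number 11 percentage points higher from compound 1 to compound 4 (beyond the scatter) in this series, so the response here depends on the ring as well as on the group capping its nitrogen. Nothing at hand explains either rise.

As far as these compounds go, whether a free amine or a carboxylic acid could replace that acetyl and keep the response remains open. So does the effect of a longer chain leading to the piperidine ring.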